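Phenylpiperazinyl amide in the styrylquinoline-like series

The source may hold more compounds than are shown below. What is called first, only, known or untested is meant among the compounds shown, and "the series" means these compounds.

Working notes. In an ADME assay on J774 cells (Mus musculus) for cytotoxicity, read by MTT assay, with a stated time of 48 h (on this read-out higher numbers stand for weaker inhibition and lower numbers for stronger inhibition), compound 1 `CC(C)(C)OC(=O)NCCNc1cc(/C=C/c2ccccc2)nc2ccccc12` gives 6600 nM and compound 2 `NCCCCNc1cc(/C=C/c2ccccc2)nc2ccccc12` gives 6600 nM; the step of no change at the digits printed from compound 1 to compound 2 (within the scatter). Compound 3 `CCN(CC)CC(=O)NCCNc1cc(/C=C/c2ccccc2)nc2ccccc12` gives 700 nM in this assay, the lowest number of the three, beyond the scatter from both others: the steps were a 9.4-fold lower number from compound 1 to compound 3 (0.97 log units; beyond the scatter) and a 9.4-fold lower number from compound 2 to compound 3 (0.97 log units; beyond the scatter).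

Compound 4 `O=C(CN1CCN(c2ccccc2)CC1)NCCNc1cc(/C=C/c2ccccc2)nc2ccccc12` differs from compound 3 by 4-phenylpiperazin-1-yl in place of diethylamino on a saturated chain carbon bound to a carbonyl carbon. For the measured compounds named here, no measured step touches this position; the steps into compound 3 change what sits on the carbonyl carbon or the chain, not the amine on the chain carbon. They show only that the amide with a tertiary amine side chain goes with the lowest number seen. Going by the values given here, compound 4 keeps that arrangement, so the number is expected near that of compound 3, with a wide range because no pair here varies the amine itself. Compound 4 is expected to give 500 nM in this assay, between 150 nM and 2500 nM, a step of a 1.4-fold lower number from compound 3 to compound 4 (0.15 log units; within the scatter).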

Compound 4, half-maximal inhibitory concentration: 4500 nM
For compound 4 the middle estimate is 9.0-fold (0.95 log units) below the measured one; measured number outside the range, above it.
By their numbers in this assay, from the lowest: compound 3; then compounds 4, 1 and 2 (each within the scatter of the next).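

In this assay, for the compounds shown here, the amine on the saturated chain carbon bound to a carbonyl carbon proves not to be interchangeable: 4-phenylpiperazin-1-yl in place of diethylamino gives a 6.4-fold higher number from compound 3 to compound 4 (0.81 log units; beyond the scatter) and is the first step at this position. The low number of compound 3 therefore does not follow from the amide with a tertiary amine side chain alone, but depends on which amine sits on that chain carbon. No measured evidence here accounts for the shift.

This single step does not separate the six-membered non-aromatic ring from the phenyl group that it carries. The 4-methylpiperazin-1-yl and piperidin-1-yl groups at the same place would bear on that, while dimethylamino would test how far the number of compound 3 holds among smaller amines.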